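Swapping the aryl group on a quinoline thiosemicarbazone

The source may report more compounds than this note shows. Statements on the series, on what has been measured and on what is new or still open speak of the compounds shown alone.

Compound 1, `COc1cccc(NC(=S)N/N=C/c2ccc3ccccc3n2)c1`, is tested in a functional assay on SGC-7901 cells (Homo sapiens) for antiproliferative activity, read by sulforhodamine B assay, with a stated time of 72 h (a lower number here means a stronger inhibitor, a higher number a weaker inhibitor), where compound 1 gives 79400 nM. That is the highest of the three numbers seen: compound 3, `CN(C)C(=S)N/N=C/c1nc2ccccc2s1`, gives 830 nM, and compound 2, `CN(C)C(=S)N/N=C/c1cnc2ccccc2n1`, gives 170 nM, both well beyond the scatter from compound 1. Compound 4, `S=C(N/N=C/c1ccc2ccccc2n1)Nc1ccccc1Br`, differs from compound 1 in one place: 2-bromophenyl in place of 3-methoxyphenyl on an amide-type nitrogen. No comparable change has been measured here, so only a cautious expectation is possible. The step of a 1.6-fold lower number from compound 1 to compound 4 (0.20 log units; within the scatter) is expected to be small, at most a modest move toward a lower number and possibly none beyond the scatter. Compound 4 is therefore estimated at 50000 nM, within a range from 15000 nM to 150000 nM.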

Compound 4, half-maximal inhibitory concentration: > 100000 nM
Compound 4 was reported as a limit; the forecaster's own chance of this, stated with the estimate: 10%; middle value at least 2.0-fold (0.30 log units) away from the limit.
By their numbers in this assay, from the lowest: compound 2; then compound 3; then compound 1. At a limit, above all of these: compound 4.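

In this assay compound 4 gives > 100000 nM, which is a limit of the assay and not a number. On the amide-type nitrogen, 2-bromophenyl in place of 3-methoxyphenyl gives an at least 1.2-fold higher number from compound 1 to compound 4 (0.10 log units; that floor lies within the scatter), so this change brings no move toward a lower number. How far the number really rises cannot be read, because the reading ends at a limit: the limit of > 100000 nM in this assay, at which 1 of the 4 values shown sits.

Still open, going by these compounds, is how this position would respond to a plain phenyl ring, a short ethyl chain or a morpholine ring. On these data alone, whether any group there could bring the number down also remains unknown.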